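Lengthening the Alkyne Chain from Compound 3 to Compound 4

The source may hold more compounds than are shown below. What is called first, only, known or untested is meant among the compounds shown, and "the series" means these compounds.

In a physicochemical assay for pharmacokinetics, read by LC-MS, in phosphate buffer, tested at 1 uM (on this read-out lower numbers stand for a shorter-lived compound and higher numbers for a longer-lived compound), compound 1 `Cc1cc2c(C(=O)NCC#N)cccc2n1-c1nc2c(c(NCc3ccccc3)n1)CCCC2` gives > 24 h which is a limit of the assay and not a number. Compound 2 `C#CC(=O)Nc1cccc2c1cc(C)n2-c1nc2c(c(NCc3ccccc3)n1)CCCC2` gives 0.21 h and compound 3 `CC#CC(=O)Nc1cccc2c1cc(C)n2-c1nc2c(c(NCc3ccccc3)n1)CCCC2` gives 16.4 h which is the higher of the two actual numbers. Compound 3 also sits close to the limit of compound 1, since the step of an at least 1.4-fold lower number from compound 1 to compound 3 (0.16 log units; that floor lies within the scatter) has a floor that lies within the scatter.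

Compound 4 `CCC#CC(=O)Nc1cccc2c1cc(C)n2-c1nc2c(c(NCc3ccccc3)n1)CCCC2` differs from compound 3 by methyl in place of hydrogen on a saturated chain carbon bound to a triple-bonded carbon with methyl in place of hydrogen on a saturated chain carbon bound to a triple-bonded carbon, so that prop-1-yn-1-yl becomes but-1-yn-1-yl.

Among the measured compounds shown here, the nearest precedent is the large step of a 78-fold higher number from compound 2 to compound 3 (1.89 log units; beyond the scatter) in which methyl replaced hydrogen on the triple-bonded carbon itself. The new methyl enters one carbon further out, and compound 3 already carries a chain at that place, so that large step should not simply repeat. The step of an at least 110-fold lower number from compound 1 to compound 2 (2.05 log units; beyond the scatter) concerns a different exchange and bears on this one only loosely.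

The expected change is a 1.2-fold higher number from compound 3 to compound 4 (0.09 log units; within the scatter) and it is expected to stay small, with a slight lean upward. In this assay compound 4 is estimated at 20 h with 9 h to 45 h as the expected range.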

Compound 4, half-life: 13.5 h
Compound 4: the middle estimate sits 1.5-fold (0.17 log units) above what was measured; low and high end bracket the measured number.
By their numbers in this assay, from the lowest: compound 2; then compounds 4 and 3 (each within the scatter of the next). At a limit, above all of these: compound 1.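

In this assay, methyl in place of hydrogen on a saturated chain carbon bound to a triple-bonded carbon, which turns prop-1-yn-1-yl into but-1-yn-1-yl, gives a 1.2-fold lower number from compound 3 to compound 4 (0.08 log units; within the scatter). The large gap to the compound with only hydrogen on the triple-bonded carbon remains when ethyl takes the place of that hydrogen, a 64-fold higher number from compound 2 to compound 4 (1.81 log units; beyond the scatter), so among the compounds shown, methyl and ethyl on that carbon both give a much longer half-life than hydrogen does, and the added methyl on the saturated chain carbon contributes no readable change. The exchange of groups on an aromatic carbon gives an at least 1.7-fold lower number from compound 1 to compound 4 (0.24 log units; that floor lies within the scatter). This step cannot be read as a size, because compound 1 stands at a limit of the assay and not at a number: the limit of > 24 h in this assay, at which 1 of the 4 values shown sits.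

As far as these compounds go, whether this flat response continues for a longer chain such as pentyl, or for a branched group such as tert-butyl on the triple-bonded carbon, remains open. Also open are a chain ending in an amine or a carboxylic acid, and why hydrogen on that carbon stands so far from methyl and ethyl.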